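The source may hold more compounds than are shown below. What is called first, only, known or untested is meant among the compounds shown, and "the series" means these compounds.

Measured so far in a functional assay on KB cells (Homo sapiens) for cytotoxicity; a lower number here means that less compound is needed, a higher number that more compound is needed for the effect
- compound 1 `COC1=C(C)C(=O)/C(=C(O)/C=C/c2cccc(OC)c2)C(=O)C1(C)C` gives 2.4 ug/mL
- compound 2 `COC1=C(C)C(=O)/C(=C(O)/C=C/c2ccccc2OC)C(=O)C1(C)C` gives 2.8 ug/mL
- compound 3 `CCc1ccc(/C=C/C(O)=C2/C(=O)C(C)=C(OC)C(C)(C)C2=O)cc1` gives 1.9 ug/mL

The value of compound 3 cannot be told apart from the other two, as the steps show: a 1.3-fold lower number from compound 1 to compound 3 (0.10 log units; within the scatter) and a 1.5-fold lower number from compound 2 to compound 3 (0.17 log units; within the scatter) are both small. Compound 4 `COC1=C(C)C(=O)/C(=C(O)/C=C/c2cc(C)cc(C)c2)C(=O)C1(C)C` carries 3,5-dimethylphenyl in place of 4-ethylphenyl on a double-bonded chain carbon bound to a double-bonded chain carbon, and 3,5-dimethylphenyl in place of 4-ethylphenyl on a double-bonded chain carbon bound to a double-bonded chain carbon gives the count. The third swap at this place, a 1.2-fold higher number from compound 1 to compound 2 (0.07 log units; within the scatter), was also small. Going by the values given here, no measured compound carries 3,5-dimethylphenyl, so this guide is rough. The expected change is a 1.2-fold higher number from compound 3 to compound 4 (0.08 log units; within the scatter), with nothing expected beyond the scatter. For compound 4 the estimated value is 2.3 ug/mL, with an expected range from 1.2 ug/mL to 4.5 ug/mL in this assay.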

Compound 4, concentration for half-maximal effect: 1.6 ug/mL
Estimate against measurement, compound 4: 1.4-fold (0.16 log units) above; the range from low to high includes it.
By their numbers in this assay, from the lowest: compounds 4, 3, 1 and 2 (each within the scatter of the next).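

In this assay, 3,5-dimethylphenyl in place of 4-ethylphenyl gives a 1.2-fold lower number from compound 3 to compound 4 (0.07 log units; within the scatter) and in place of the methoxyphenyl groups gives a 1.8-fold lower number from compound 2 to compound 4 (0.24 log units; within the scatter) and a 1.5-fold lower number from compound 1 to compound 4 (0.18 log units; within the scatter) with all three steps inside the scatter. On the double-bonded chain carbon, then, a phenyl ring bearing two methyl groups cannot be told apart from one bearing a single ethyl or methoxy group. On these data alone, whether an amine or a carboxylic acid on this phenyl ring, or a longer chain in its place, would shift the number stays open. No measurement shown explains why these values stay so close.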